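The source may hold more compounds than are shown below. What is called first, only, known or untested is meant among the compounds shown, and "the series" means these compounds.

Compound 1 `C=CC1=C(C(=O)NCCC)C(c2ccc(OC)c(OC)c2)OC1` was tested in a functional assay on A549 cells (Homo sapiens) for cytotoxicity, read by MTT assay, with a stated time of 24 h; on this read-out higher numbers stand for weaker inhibition and lower numbers for stronger inhibition. In this assay compound 1 gives > 100000 nM, which is a limit of the assay rather than a measured number. Two companions share its core. Compound 2 `C=CC1=C(C(=O)NCc2ccccc2F)C(c2ccc(F)cc2)OC1` gives > 100000 nM in this assay, again a limit. Compound 3 `C=CC1=C(C(=O)NCCC)C(c2ccc(F)cc2)OC1` gives > 100000 nM in this assay, also a limit. Among the measured compounds shown here, the only single-point step among them, ethyl in place of 2-fluorophenyl on a saturated chain carbon bound to an amide-type nitrogen, is a step that the two limits leave unreadable from compound 2 to compound 3, so its size cannot be read. All that the numbers show is the limit of > 100000 nM in this assay, at which 3 of the 3 values shown sit. Compound 1 thus stands at that limit together with the other two, and no ordering among the three can be drawn.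

Compound 4 `C=CC1=C(C(=O)O)C(c2ccc(OC)c(OC)c2)OC1` differs from compound 1 in one place: hydroxy in place of propylamino on a carbonyl carbon. The same difference, cut one bond further out, reads propylcarbamoyl to carboxy. For the measured compounds named here, no measured step touches this change, and the one step that was measured is unreadable, so no size or direction beyond the scatter can be read for it in this assay. Going by the values given here, since every compound so far sits at the limit, compound 4 is expected to sit there too, and the expected step is a step that the limit leaves unreadable from compound 1 to compound 4. The estimate for compound 4 is 150000 nM, expected to fall between 50000 nM and 1000000 nM.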

Compound 4, half-maximal inhibitory concentration: > 100000 nM
Compound 4 gave a limit, no number; the forecaster's own chance of this, stated with the estimate: 85%; the middle value is on the limit's open side.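

Compound 1 and compound 4 each give only a limit rather than a number in this assay, so no new step can be read between them, and the same holds for all the compounds shown: the limit of > 100000 nM in this assay, at which 4 of the 4 values shown sit.

The compounds shown leave open what hydroxy in place of propylamino on a carbonyl carbon does to the read-out, and whether any of these four compounds would give a measured number in this assay.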